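Compound 2 to compound 4: a solubility estimate

A few compounds are considered here, and "the series" means these few. Any claim that something is new, unique, unknown or untested is made for them only; others in the source may bear on it.

Values so far in a physicochemical assay for solubility, read by HPLC, at pH 7.4 (a lower number here means a less soluble compound, a higher number a more soluble compound), for the three measured compounds
Compound 1 `CCCCCCCc1[nH]c2ccc([N+](=O)[O-])cc2c(=O)c1CO` gives 5000 nM
Compound 2 `CCCCCCCc1[nH]c2ccc([N+](=O)[O-])cc2c(=O)c1C(=O)OCC` gives 5000 nM
Compound 3 `CCOCCCCc1[nH]c2ccc([N+](=O)[O-])cc2c(=O)c1C(=O)OCC` gives 5000 nM

Compound 2 stands level with compound 1 and compound 3 at these digits. The change to compound 4 `CCCCCCCc1[nH]c2ccc([N+](=O)[O-])cc2c(=O)c1C(=O)NO` is hydroxyamino in place of ethoxy on a carbonyl carbon. Among the compounds with values here, two measured steps bear on it. Ethoxycarbonyl in place of hydroxymethyl gave no change at the digits printed from compound 1 to compound 2 (within the scatter) and is the closer precedent, and ethoxy in place of propyl on the chain gave no change at the digits printed from compound 2 to compound 3 (within the scatter) as well. Within the data shown here, no measured step introduces hydroxyamino, so the precedent is indirect and no direction can be assigned. The expected step is no change at the digits printed from compound 2 to compound 4 (within the scatter) in this series. Compound 4 is estimated at 5000 nM with an expected range of 2500 nM to 10000 nM in this read-out.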

Compound 4, solubility: > 200000 nM
Compound 4: a limit, no number (the forecaster's own chance of this, stated with the estimate: 15%); at least 40-fold (1.60 log units) between middle value and limit.
By their numbers in this assay, from the lowest: compounds 1, 2 and 3 (each within the scatter of the next). At a limit, above all of these: compound 4.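

Among the changes shown, hydroxyamino in place of ethoxy on a carbonyl carbon is the only one that moves this assay, giving an at least 40-fold higher number from compound 2 to compound 4 (1.60 log units; beyond the scatter). Hydroxycarbamoyl in place of hydroxymethyl on an aromatic carbon gives an at least 40-fold higher number from compound 1 to compound 4 (1.60 log units; beyond the scatter). Compound 4 gives > 200000 nM in this assay, which is a limit and not a number.

Open, on these data alone, is whether this step needs hydroxyamino itself or would also follow from an amine or a hydroxyl on the same carbonyl carbon, as in a primary amide or a carboxylic acid. Also open, as far as these compounds go, is whether it carries over to the ethoxy-bearing chain of compound 3.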